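From Fluorophenyl to Dichlorophenyl at the Ring Nitrogen

The compounds below may be only part of what the source reports. "The series", "measured", "known", "first", "only" and "open" are said of these compounds alone.

Three compounds share one core and differ only in the aryl group on an amine nitrogen in a ring. In an assay on CHO cells for displacement of a labelled ligand from adenosine receptor A3 (Homo sapiens), read by scintillation counting, with a stated time of 120 min, tested at 10 uM (a higher number here means more inhibition at the concentration tested (going by the name of the read-out), a lower number less inhibition), compound 1 `COc1ccc(N2CCN(Cc3csc(N)c3C(=O)c3ccc(Cl)cc3)CC2)cc1` gives 0%. Compound 2 `Nc1scc(CN2CCN(c3ccncc3)CC2)c1C(=O)c1ccc(Cl)cc1` gives 2% in this assay, and compound 3 `Nc1scc(CN2CCN(c3cccc(F)c3)CC2)c1C(=O)c1ccc(Cl)cc1` gives 4%. The steps among them are all small: a number 2 percentage points higher from compound 1 to compound 2 (within the scatter), a number 4 percentage points higher from compound 1 to compound 3 (within the scatter) and a number 2 percentage points higher from compound 2 to compound 3 (within the scatter). Compound 3 carries the largest of the three figures in arithmetic only, since its gaps to compound 2 and to compound 1 both lie within the scatter, so none of the three can be set apart.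

Compound 4 `Nc1scc(CN2CCN(c3cc(Cl)ccc3Cl)CC2)c1C(=O)c1ccc(Cl)cc1` continues the same exchange: 2,5-dichlorophenyl in place of 3-fluorophenyl on an amine nitrogen in a ring. Every step measured so far at this nitrogen, whether to pyridin-4-yl or to 3-fluorophenyl, stayed within the scatter, so a step of a number 1 percentage points higher from compound 3 to compound 4 (within the scatter) is expected, with no movement beyond the scatter. Compound 4 is therefore estimated at 5% in this assay, within a range from 0% to 15%.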

Compound 4, a percentage reported as inhibition, at one concentration (the size of the read-out at that concentration, not a potency): 1%
Beside the measured number, compound 4's estimate is 4 percentage points above it; the range from low to high includes it.
By their numbers in this assay, from the lowest: compounds 1, 4, 2 and 3 (each within the scatter of the next).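

In this assay the 2,5-dichlorophenyl group gives a number 3 percentage points lower from compound 3 to compound 4 (within the scatter) and a number 1 percentage points lower from compound 2 to compound 4 (within the scatter) and also a number 1 percentage points higher from compound 1 to compound 4 (within the scatter) so the four compounds still cannot be set apart. None of the earlier groups at this position carried chlorine, and the new compound shows that a phenyl ring with two chlorine atoms on the amine nitrogen in a ring also stays within the scatter of all three others. Nothing available here accounts for this flat picture.

From the compounds shown here alone, whether a carboxylic acid or a primary amine on the phenyl ring, or a longer alkyl chain in place of the ring, would give a step beyond the scatter stays open. So does whether a change away from this nitrogen, elsewhere on the shared core, would move the number at all.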